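The compounds below may be only part of what the source reports. "The series", "measured", "known", "first", "only" and "open" are said of these compounds alone.

Measured compounds in a functional assay on A549 cells (Homo sapiens) for cytotoxicity, read by MTT assay, with a stated time of 72 h; on this read-out lower numbers stand for stronger inhibition and higher numbers for weaker inhibition:

- compound 1 `Cc1cc(/C=N/NC(=O)Nc2ccc(Oc3ccnc(-c4nncn4CCN(C)C)c3)c(F)c2)cc(C)c1O`: 1640 nM
- compound 2 `COc1ccc(/C=N/NC(=O)Nc2ccc(Oc3ccnc(-c4nncn4CCN(C)C)c3)c(F)c2)c(OC)c1`: 2820 nM
- compound 3 `COc1ccc(/C=N/NC(=O)Nc2ccc(Oc3ccnc(-c4nncn4CCN(C)C)c3)c(F)c2)cc1O`: value given only as a limit, see below

Compound 1 and compound 2 sit within the scatter of each other, a 1.7-fold higher number from compound 1 to compound 2 (0.24 log units; within the scatter). Compound 3 reports no number; in this assay compound 3 stands at the limit > 100000 nM, which is a limit of the assay (the limit of > 100000 nM in this assay, at which 1 of the 3 values shown sits). Compound 3 is therefore the weakest of the three, with an at least 60-fold higher number from compound 1 to compound 3 (1.78 log units; beyond the scatter) and an at least 35-fold higher number from compound 2 to compound 3 (1.54 log units; beyond the scatter).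

Compound 4 `CN(C)CCn1cnnc1-c1cc(Oc2ccc(NC(=O)N/N=C/c3ccc(O)cc3O)cc2F)ccn1` is not yet measured. It differs from compound 3 by 2,4-dihydroxyphenyl in place of 3-hydroxy-4-methoxyphenyl on a carbon with a double bond to nitrogen. The measured steps that bear on it are those into compound 3, both large and both rising to the limit. The change from compound 3 to compound 4 removes the 3-hydroxy-4-methoxyphenyl that carries the limit and brings a 2,4-substituted ring, a pattern that compound 2, with its 2,4-dimethoxyphenyl, shows with a measured number. Going by the values given here, a step downward, beyond the scatter, is therefore expected, though the size is uncertain because the hydroxy groups of compound 4 have no measured counterpart. For compound 4 the expected step is an at least 8.3-fold lower number from compound 3 to compound 4 (0.92 log units; beyond the scatter). Compound 4 is estimated at 12000 nM, with a range from 2000 nM to 100000 nM.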

Compound 4, half-maximal inhibitory concentration: 12700 nM
Compound 4: the middle estimate sits 1.1-fold (0.02 log units) below what was measured; low and high end bracket the measured number.
By their numbers in this assay, from the lowest: compounds 1 and 2 (each within the scatter of the next); then compound 4. At a limit, above all of these: compound 3.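

Compound 3 stays at a limit of the assay: the limit of > 100000 nM in this assay, at which 1 of the 4 values shown sits. In this assay, 2,4-dihydroxyphenyl in place of 3-hydroxy-4-methoxyphenyl gives an at least 7.8-fold lower number from compound 3 to compound 4 (0.89 log units; beyond the scatter), so a hydroxy group on this ring does not by itself put a compound at the limit, and compound 1 also carries one with a measured number. The 2,4-dihydroxyphenyl ring still does not match the other two rings, with a 4.5-fold higher number from compound 2 to compound 4 (0.65 log units; beyond the scatter) for the exchange of the two methoxy groups for hydroxy groups, and a 7.7-fold higher number from compound 1 to compound 4 (0.89 log units; beyond the scatter) against the 4-hydroxy-3,5-dimethylphenyl ring.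

On these data alone, whether the gap between compound 3 and compound 4 follows from the methoxy group or from where the hydroxy groups sit stays open, and the limit gives that gap no upper size. Also open, as far as these compounds go, is how an amine or a carboxylic acid on this ring would read in this assay.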